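Phenethyl in place of 4-fluorophenyl at the carbonyl

This account rests on a few compounds, and the source may have more. Where it says the series, first, only, none or still open, it means among the compounds named here.

Two compounds with a shared core were tested in an ADME assay on L929 cells (Mus musculus) for cytotoxicity, read by resazurin assay, with a stated time of 72 h; a lower number here means a stronger inhibitor, a higher number a weaker inhibitor. Compound 1, with structure `CCCNC(=O)c1cccn1-c1ccc2c(c1)B(O)OC2`, gave > 10 ug/mL in this assay, which is a limit of the assay and not a number. Compound 2, with structure `O=C(c1ccc(F)cc1)c1ccn(-c2ccc3c(c2)B(O)OC3)c1`, likewise gave > 10 ug/mL in this assay, again only a limit. Compound 2 therefore stands where both measured values sit, namely at the limit of > 10 ug/mL in this assay, at which 2 of the 2 values shown sit. Compound 3, with structure `O=C(CCc1ccccc1)c1ccn(-c2ccc3c(c2)B(O)OC3)c1`, has not yet been measured in this assay. It differs from compound 2 by phenethyl in place of 4-fluorophenyl on a carbonyl carbon. Among the compounds with values here, no pair of measured compounds differing in one place is available, so no step size in this assay is known. Because compound 2 sits at the limit of > 10 ug/mL in this assay, at which 2 of the 2 values shown sit, the step is expected to stay within the usual scatter, with no clear direction. The expected step from compound 2 to compound 3 is a step that the limit leaves unreadable from compound 2 to compound 3. Compound 3 is accordingly estimated at 15 ug/mL in this assay, in the range 5 ug/mL to 45 ug/mL.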

Compound 3, half-maximal inhibitory concentration: > 10 ug/mL
Compound 3 was reported as a limit; the forecaster's own chance of this, stated with the estimate: 70%; the middle value is on the limit's open side.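

The step from compound 2 to compound 3 cannot be read, as both are reported only as limits of the assay. The compounds shown leave open where any of them lies beyond that limit in this assay, and whether exchanging 4-fluorophenyl for phenethyl changes the value at all: the limit of > 10 ug/mL in this assay, at which 3 of the 3 values shown sit.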